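This account rests on a few compounds, and the source may have more. Where it says the series, first, only, none or still open, it means among the compounds named here.

Compound 1 `Fc1ccc(-c2nn3c(NC4CCCC4)cccc3c2-c2cccnc2)cc1` is characterised in an ADME assay on Vero cells (Chlorocebus sabaeus) for cytotoxicity; a lower number here means that less compound is tolerated, a higher number that more compound is tolerated. In this assay compound 1 shows only an assay limit, > 40000 nM, so no true number is known for it. Compound 2 `Fc1ccc(-c2nn3c(NC4CCCC4)cccc3c2-c2ccnc(NC3CCCC3)n2)cc1` in this assay likewise shows only a limit, > 160000 nM. Compound 1 thus stands at one of the two limits, (the limit of > 40000 nM in this assay, at which 1 of the 2 values shown sits), while the other is the limit of > 160000 nM in this assay, at which 1 of the 2 values shown sits. Compound 3 `Nc1n[nH]cc1-c1c(-c2ccc(F)cc2)nn2c(NC3CCCC3)cccc12` carries 3-amino-1H-pyrazol-4-yl in place of pyridin-3-yl on an aromatic carbon. Within the data shown here, with no measured step to draw on, the step that the limit leaves unreadable from compound 1 to compound 3 is expected to be small, nothing beyond the usual scatter. For compound 3 the estimated value is 60000 nM, ranging from 20000 nM to 200000 nM.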

Compound 3, half-maximal cytotoxic concentration: 20000 nM
Beside the measured number, compound 3's estimate is 3.0-fold (0.48 log units) above it; measured number inside the range.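

Replacing pyridin-3-yl with 3-amino-1H-pyrazol-4-yl on this aromatic carbon gives, in this assay, an at least 2.0-fold lower number from compound 1 to compound 3 (0.30 log units; that floor lies within the scatter). Going by these compounds, compound 3 thus gives a true number for a group at this position, while the true size of the step remains unknown. Compound 1 stands at a limit of the assay: the limit of > 40000 nM in this assay, at which 1 of the 3 values shown sits.

The compounds shown leave open whether the change follows from the amino group or from the five-membered ring. A plain 1H-pyrazol-4-yl or a pyridin-3-yl carrying an amine at this position would separate the two.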